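The source may hold more compounds than are shown below. What is called first, only, known or untested is meant among the compounds shown, and "the series" means these compounds.

Measured so far:
Compound 1 `O=c1[nH]/c(=N\OCCCCc2ccccc2)ccn1[C@@H]1O[C@H](COP(=O)(O)OP(=O)(O)OP(=O)(O)O)[C@@H](O)[C@H]1O` gives 251 nM in a functional assay on 1321-N1 cells for agonist activity at P2Y purinoceptor 6 (Homo sapiens), read by scintillation counting and inositol phosphate accumulation; on this read-out higher numbers stand for an effect only at larger amounts of compound and lower numbers for an effect already at smaller amounts.
Compound 2 `O=c1[nH]/c(=N\OCCCc2ccsc2)ccn1[C@@H]1O[C@H](COP(=O)(O)OP(=O)(O)OP(=O)(O)O)[C@@H](O)[C@H]1O` gives 164 nM in this assay.

Going by the values given here, compound 2 sits beside compound 1 on these numbers: the only measured step, a 1.5-fold lower number from compound 1 to compound 2 (0.18 log units; within the scatter), is within the scatter. Compound 3 `C#CCCCO/N=c1/ccn([C@@H]2O[C@H](COP(=O)(O)OP(=O)(O)OP(=O)(O)O)[C@@H](O)[C@H]2O)c(=O)[nH]1` differs from compound 2 by ethynyl in place of thiophen-3-yl on a saturated chain carbon, three bonds along the chain from an oxygen. Among the compounds with values here, no measured step bears on this change; the one known step exchanges one ring for another, whereas here the ring leaves and only a short alkyne remains. A step toward higher numbers, a 2.7-fold higher number from compound 2 to compound 3 (0.44 log units; beyond the scatter), is therefore expected, though with wide uncertainty. Compound 3 is estimated at 450 nM, in a range from 150 nM to 1400 nM.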

Compound 3, half-maximal effective concentration: 3000 nM
Estimate against measurement, compound 3: 6.7-fold (0.82 log units) below, outside the stated range (above it).
By their numbers in this assay, from the lowest: compounds 2 and 1 (each within the scatter of the next); then compound 3.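

Exchanging one ring for another at this place on the chain had stayed within the scatter, but losing the ring altogether does not: the change to ethynyl gives an 18-fold higher number from compound 2 to compound 3 (1.26 log units; beyond the scatter), and the same change from the benzyl side gives a 12-fold higher number from compound 1 to compound 3 (1.08 log units; beyond the scatter). Among these compounds, then, both ring-bearing chain ends give clearly lower numbers than the short alkyne. Nothing available explains the size of this step. The compounds shown leave open whether a cyclohexyl ring or a longer saturated alkyl chain would keep the lower numbers, and how an amine or a carboxylic acid would fare at this place.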